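This account rests on a few compounds, and the source may have more. Where it says the series, first, only, none or still open, it means among the compounds named here.

Working notes on the series.

Compound 2 `COc1nc2ccc(Br)cc2cc1C(c1ccccc1)n1cc(-c2cccc(F)c2)nn1` is the lower of the two measured compounds in an ADME assay on HEK293 cells (Homo sapiens) for cytotoxicity, read by sulforhodamine B assay, with a stated time of 48 h, tested at 10 uM; on this read-out higher numbers stand for more inhibition at the one concentration tested (going by the name of the read-out) and lower numbers for less inhibition: compound 2 gives 6.84%. Going by the values given here, its only measured neighbour is compound 1 `COc1nc2ccc(Br)cc2cc1C(c1ccccc1)n1cc(CCCO)nn1`, which in this assay gives 27.4%; the single measured step is a number 20.6 percentage points lower from compound 1 to compound 2 (beyond the scatter), and it is beyond the scatter.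

Compound 3 `COc1nc2ccc(Br)cc2cc1C(c1ccccc1)n1cc(C2CC2)nn1` differs from compound 2 by cyclopropyl in place of 3-fluorophenyl on an aromatic carbon. Among the compounds with values here, no measured step involves cyclopropyl at this position, so the only guidance is that the step from compound 1 to compound 2 showed the reading at this attachment point can move by a modest amount, with the 3-fluorophenyl end lying low. Whether cyclopropyl behaves more like 3-fluorophenyl or more like 3-hydroxypropyl cannot be read from the two values available. The expectation is therefore placed between the two measured readings: the step from compound 2 to compound 3 is expected to be a number 8.2 percentage points higher from compound 2 to compound 3 (within the scatter), upward but of a size that may or may not exceed the scatter. Compound 3 is accordingly expected to give about 15% in this assay, with a range from 0% to 32% in view of the absence of any directly comparable step.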

Compound 3, a percentage reported as inhibition, at one concentration (the size of the read-out at that concentration, not a potency): 8.22%
Compound 3: middle estimate off by 6.8 percentage points, on the high side, and the stated range covers the measured number.
By their numbers in this assay, from the lowest: compounds 2 and 3 (each within the scatter of the next); then compound 1.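

Working from this assay, the exchange of 3-fluorophenyl for cyclopropyl gives a number 1.4 percentage points higher from compound 2 to compound 3 (within the scatter) at this aromatic carbon, so a group of 3 heavy atoms with a three-membered non-aromatic ring cannot be told apart here from a group of 7 heavy atoms with a six-membered aromatic ring. Replacing 3-hydroxypropyl now has a second reading, a number 19.2 percentage points lower from compound 1 to compound 3 (beyond the scatter), and among these three compounds both ring-bearing groups therefore sit apart from the 3-hydroxypropyl group, with no compound shown going against that. No measurement at hand explains this separation.

Still open, as far as these compounds go, is whether the higher reading of compound 1 goes with the hydroxyl at the end of the chain or with the open chain itself, a question that a plain propyl chain, a longer chain, an amine or a carboxylic acid at this carbon could help to settle. Also open, from the compounds shown here alone, is whether the same separation would hold with the rest of the shared core changed.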